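A few compounds are considered here, and "the series" means these few. Any claim that something is new, unique, unknown or untested is made for them only; others in the source may bear on it.

Three related compounds have been tested in a functional assay on Bel-7402 cells (Homo sapiens) for inhibition, read by MTT assay, with a stated time of 24 h, tested at 1 ug/mL; a lower number here means less inhibition of growth, a higher number more inhibition of growth at the concentration tested. In this assay, compound 1 (`O=C(CCCCC(S)CCS)NO`) gives 9.12% and compound 3 (`O=C(CCCCC1CCSS1)Nc1ccc(Br)cn1`) gives 13.1%, two values within the usual scatter of each other. Compound 2 (`O=C(CCCCC1CCSS1)Nc1ccccn1`) has no single number, and its result reads "not active" (no number reported). Compound 4 (`O=C(CCCCC(S)CCS)Nc1ccccn1`) has not been measured yet. The structural change is a group of 5 heavy atoms (3 carbon, 2 sulfur; no ring) in place of a group of 5 heavy atoms (3 carbon, 2 sulfur; one five-membered non-aromatic ring with 2 hetero atoms), on a saturated chain carbon, four bonds along the chain from a carbonyl carbon. The 1,3-disulfanylpropyl group also occurs in compound 1, which gives 9.12%, although that compound differs from compound 4 elsewhere too. A small rise in this assay is therefore expected, possibly none beyond the scatter. For compound 4 the estimated value is 9%, with an expected range from 0% to 22%.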

Compound 4, percent growth inhibition at one concentration: "not active" (no number reported)
Compound 4 has no reported number here, so the estimate cannot be set against anything.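

Compound 2 and compound 4 both read "not active", without a number, in this assay, so no step can be read between them. No supporting evidence bears on this result. The compounds shown leave open whether exchanging the five-membered ring for 1,3-disulfanylpropyl changes growth inhibition at all.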